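The compounds below may be only part of what the source reports. "The series", "measured", "known", "first", "only" and "open" are said of these compounds alone.

Working notes on the series.

The set comprises compound 1 `Fc1ccc(-c2cc(-c3ccc4cc(F)ccc4n3)nn2-c2ccccc2)cc1`, compound 2 `COc1ccc(-c2cc(-c3ccc4cc(F)ccc4n3)nn2-c2ccccc2)cc1`, compound 3 `Fc1ccc(-n2nc(-c3ccccc3)cc2-c2ccc3cc(F)ccc3n2)cc1` and the unmeasured compound 4 `COc1ccc(-n2nc(-c3ccccc3)cc2-c2ccc3cc(F)ccc3n2)cc1`. Compound 1 and compound 3 carry the same atoms joined differently; the difference between the two cores is not broken down here.

In an ADME assay on Huh-7 cells (Homo sapiens) for cytotoxicity, read by XTT assay, with a stated time of 3 days, tested at 20 uM (a higher number here means a weaker effect of the compound at the concentration tested, a lower number a stronger effect), compound 1 gives 88.3%. Compound 2 gives 95.6% in this assay. Compound 3 gives 97.8% in this assay, and its numbers and those of compound 1 and compound 2 lie within the scatter of one another.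

The change from compound 1 to compound 2 is methoxy in place of fluoro on an aromatic carbon, and it made a step of a number 7.3 percentage points higher from compound 1 to compound 2 (within the scatter). The change from compound 3 to compound 4 is methoxy in place of fluoro on an aromatic carbon, the same change at the same place on the other core.

For compound 4 the step in this assay is expected to be a number 1.2 percentage points higher from compound 3 to compound 4 (within the scatter), small, resting on the step of a number 7.3 percentage points higher from compound 1 to compound 2 (within the scatter) having stayed within the scatter. Compound 4 is therefore estimated at 99%, between 90% and 106%.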

Compound 4, a percentage reported as activity, at one concentration (the size of the read-out at that concentration, not a potency): 116%
Compound 4: middle estimate off by 17 percentage points, on the low side; measured number above the stated range.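

In this assay, the change from 4-fluorophenyl to 4-methoxyphenyl gives a number 18.2 percentage points higher from compound 3 to compound 4 (beyond the scatter). Set beside the same change on the core of compound 1, this step cannot be told apart from the earlier one: the same change on two cores in this assay, a number 7.3 percentage points higher (within the scatter) from compound 1 to compound 2 and a number 18.2 percentage points higher (beyond the scatter) from compound 3 to compound 4, 10.9 percentage points apart, within the scatter of two such steps. Going by these compounds alone, the numbers therefore give no ground for treating the change differently on the two cores, but with a single pair on each core they do not show that the step has the same size on both, and only the step on the core of compound 3 stands clear of the scatter.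

The compounds shown leave open how other groups at this place would read on either core, for instance an amine, a carboxylic acid or a longer chain such as butoxy. They also leave open whether the change from 4-fluorophenyl to 4-methoxyphenyl would give a comparable step on any core other than these two.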